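Opening the Sugar Ring: What to Expect for Compound 4

The compounds below may be only part of what the source reports. "The series", "measured", "known", "first", "only" and "open" are said of these compounds alone.

Measured in a toxicity assay on L02 cells (Homo sapiens) for cytotoxicity, read by MTT assay, with a stated time of 72 h; a higher number here means a weaker inhibitor, a lower number a stronger inhibitor:
Compound 1, `O=C1c2c[n+]([O-])c3ccccc3c2C(=O)c2c1c1ccccc1n2Cc1cn([C@@H]2C[C@H](O)[C@@H](CO)O2)nn1`: 630 nM
Compound 2, `CC1(C)OC[C@H](Cn2cc(Cn3c4c(c5ccccc53)C(=O)c3c[n+]([O-])c5ccccc5c3C4=O)nn2)O1`: 470 nM
Compound 3, `O=C1c2c[n+]([O-])c3ccccc3c2C(=O)c2c1c1ccccc1n2CCCCN1CCCCC1`: 610 nM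

Compound 1 carries the largest of the three numbers, yet compound 3 and compound 2 both sit within the usual scatter of it, so the three are not truly separated.

Compound 4, `O=C1c2c[n+]([O-])c3ccccc3c2C(=O)c2c1c1ccccc1n2Cc1cn(C[C@@H](O)CO)nn1`, differs from compound 1 by 2,3-dihydroxypropyl in place of 4-hydroxy-5-(hydroxymethyl)oxolan-2-yl on an aromatic nitrogen. Among the measured compounds shown here, the only measured step that speaks to this change is a 1.3-fold lower number from compound 1 to compound 2 (0.13 log units; within the scatter), in which the same ring left the aromatic nitrogen and another small oxygen-bearing group took its place without moving the number beyond the scatter. The same is expected here, so in this assay compound 4 is estimated at 600 nM, between 300 nM and 1200 nM, an expected 1.1-fold lower number from compound 1 to compound 4 (0.02 log units; within the scatter).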

Compound 4, half-maximal inhibitory concentration: 490 nM
Estimate against measurement, compound 4: 1.2-fold (0.09 log units) above, and the stated range covers the measured number.
By their numbers in this assay, from the lowest: compounds 2, 4, 3 and 1 (each within the scatter of the next).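

In this assay, the step with the ring opened to 2,3-dihydroxypropyl, [ a 1.3-fold lower number from compound 1 to compound 4 (0.11 log units; within the scatter) ], shows that this aromatic nitrogen can lose the five-membered ring and its 3 defined stereocentres without the number leaving the scatter. Exchanging 2,2-dimethyl-1,3-dioxolan-4-yl for 1,2-dihydroxyethyl, [ a 1.0-fold higher number from compound 2 to compound 4 (0.02 log units; within the scatter) ], also stays within it. So does the larger exchange of 3-(piperidin-1-yl)propyl for 1-(2,3-dihydroxypropyl)-1H-1,2,3-triazol-4-yl, [ a 1.2-fold lower number from compound 3 to compound 4 (0.10 log units; within the scatter) ].

Going by these compounds, whether an amine or a carboxylic acid on this aromatic nitrogen would move the number beyond the scatter remains open. No further measurement is available to explain these results.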